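The compounds below may be only part of what the source reports. "The series", "measured", "known", "first", "only" and "open" are said of these compounds alone.

Measured in a functional assay on KBVIN cells (Homo sapiens) for cytotoxicity, read by sulforhodamine B assay; on this read-out lower numbers stand for stronger inhibition of growth and higher numbers for weaker inhibition of growth:
- Compound 1 `CCOC(=O)/C(C#N)=C/c1ccccc1-c1c(/C=C(\C#N)C(=O)OCC)cc(OC)c(OC)c1OC`: 8450 nM
- Compound 2 `COc1cc(C=C(C#N)C#N)c(-c2ccccc2C=C(C#N)C#N)c(OC)c1OC`: > 40000 nM

Among the measured compounds shown here, compound 1 gives 8450 nM, the only true number in this small set. Compound 2 reads > 40000 nM, which is a limit of the assay and not a number. Compound 1 therefore cannot be placed on a wider scale, and no exact gap to compound 2 can be stated.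

Compound 3 `CCOC(=O)/C(C#N)=C/c1ccccc1-c1c(C(=O)OC)cc(OC)c(OC)c1OC` has not yet been measured. It differs from compound 1 at one place: methoxycarbonyl in place of 2-cyano-2-(ethoxycarbonyl)ethenyl on an aromatic carbon. A methoxycarbonyl group stands in place of a 2-cyano-2-(ethoxycarbonyl)ethenyl group on an aromatic carbon.

For the measured compounds named here, no measured pair isolates this change, so the expectation starts from compound 1 at 8450 nM and is only a cautious one. In this assay, the expected result is a modest weakening close to the usual scatter, a 1.7-fold higher number from compound 1 to compound 3 (0.22 log units; within the scatter). The estimated value for compound 3 is 14000 nM, with an expected range from 5000 nM to 40000 nM.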

Compound 3, concentration for 50% growth inhibition: > 40000 nM
Compound 3: no number, only a limit; the forecaster's own chance of this, stated with the estimate: 25%; middle value at least 2.8-fold (0.45 log units) from the limit.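

In this assay, putting methoxycarbonyl in place of 2-cyano-2-(ethoxycarbonyl)ethenyl on this aromatic carbon gives an at least 4.7-fold higher number from compound 1 to compound 3 (0.67 log units; beyond the scatter), a change beyond the usual scatter. This is the first step shown that isolates a single place, and it shows that the activity of compound 1 depends on what sits at this position: the smaller ester does not retain it within the range tested. The step gives only the smallest possible size of the change, because compound 3 reaches the end of the measurable range, and the true gap cannot be read: the limit of > 40000 nM in this assay, at which 2 of the 3 values shown sit.

The compounds shown leave open which part of the departing group matters, whether its nitrile, its ethyl ester or its double bond, since all of these leave together in this one change. They also leave open how a carboxylic acid, an aminomethyl group or a longer chain ending in an ethyl ester would read on this same aromatic carbon, with the rest of compound 1 kept unchanged.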